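The compounds below may be only part of what the source reports. "The series", "measured", "known", "first", "only" and "open" are said of these compounds alone.

Working notes on the series. In an assay on L1.2 cells for binding affinity to C-C chemokine receptor type 8 (Homo sapiens) (a lower number here means a stronger inhibitor, a higher number a weaker inhibitor), compound 1 `CCOC(=O)N1CCC(NS(=O)(=O)c2ccc(C(=O)Nc3ccccc3C)c3ccccc23)CC1` gives 5.21 nM. Compound 3 `CCOC(=O)N1CCC(NS(=O)(=O)c2ccc(OC(=O)c3ccccc3)c3ccccc23)CC1` gives 16.4 nM in this assay, the highest of the two numbers in hand; its nearest neighbour is compound 1, and the step of a 3.1-fold higher number from compound 1 to compound 3 (0.50 log units; beyond the scatter) is modest. Compound 2 `CCOC(=O)N1CCC(NS(=O)(=O)c2ccc(O)c3ccccc23)CC1` sits at the limit > 5000 nM in this assay. For compound 2 only the limit of > 5000 nM in this assay, at which 1 of the 3 values shown sits, is known, so the step of an at least 300-fold lower number from compound 2 to compound 3 (2.48 log units; beyond the scatter) is read as a large one, and the step of an at least 950-fold higher number from compound 1 to compound 2 (2.98 log units; beyond the scatter) likewise.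

Not yet measured is compound 4 `CCOC(=O)N1CCC(NS(=O)(=O)c2ccc(N)c3ccccc23)CC1`, which differs from compound 3 by amino in place of benzoyloxy on an aromatic carbon. Among the measured compounds shown here, the step that bears on it is the one from compound 2 to compound 3, where a small polar group at this position on the shared core gave a number at the limit and the benzoyloxy group brought it down by a large step; the amino group of compound 4 is again a single heavy atom with a donor at this same place. A large rise in this assay is therefore expected, a 180-fold higher number from compound 3 to compound 4 (2.26 log units; beyond the scatter), with a fair chance that only a limit is reported. The estimate for compound 4 is 3000 nM, with a range from 400 nM to 20000 nM.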

Compound 4, inhibition constant: > 5000 nM
Compound 4: only a limit was reported; the forecaster's own chance of this, stated with the estimate: 50%; middle value at least 1.6-fold (0.22 log units) from the limit.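

Compound 4 in this assay gives only a limit, not a number, and it is the same limit as for compound 2: the limit of > 5000 nM in this assay, at which 2 of the 4 values shown sit.

Amino in place of benzoyloxy gives an at least 300-fold higher number from compound 3 to compound 4 (2.48 log units; beyond the scatter), and amino in place of (2-methylphenyl)carbamoyl gives an at least 950-fold higher number from compound 1 to compound 4 (2.98 log units; beyond the scatter). The loss at this aromatic carbon is therefore not particular to hydroxy, as amino also fails to hold the numbers of the two larger groups, though the step between compound 2 and compound 4 cannot be read, both values being limits.

Open, as far as these compounds go, is how much of the benzoyloxy or (2-methylphenyl)carbamoyl group is needed on the shared core. An acetamide, a methoxy group or a benzylamino group at this place would show whether a short substituent suffices or whether the phenyl ring is required.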